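The source may hold more compounds than are shown below. What is called first, only, known or untested is meant among the compounds shown, and "the series" means these compounds.

Series notes on permeability.

Measured in an ADME assay for permeability, using PAMPA; on this read-out lower numbers stand for lower permeability and higher numbers for higher permeability:
compound 1, `O=C(Nc1ccc([N+](=O)[O-])cc1)c1cc(Cl)ccc1O`, gives 127 10^-6 cm/s.
compound 2, `O=C(Nc1ccc([N+](=O)[O-])c(Cl)c1)c1cc(Cl)ccc1O`, gives 68 10^-6 cm/s.
compound 3, `O=C(Nc1ccc(Cl)cc1Cl)c1cc(Cl)ccc1O`, gives < 22.4 10^-6 cm/s, which is a limit of the assay and not a number.

For compound 3 the read-out is therefore (the limit of < 22.4 10^-6 cm/s in this assay, at which 1 of the 3 values shown sits).

For the measured compounds named here, the one measured step that changes a single place is hydrogen in place of chloro on an aromatic carbon; it amounts to a 1.9-fold higher number from compound 2 to compound 1 (0.27 log units; within the scatter). How the core of compound 3 differs from the core of compound 2 is not broken down here.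

Compound 4, `O=C(Nc1ccc(Cl)cc1)c1cc(Cl)ccc1O`, is not yet measured in this assay. It differs from compound 3 by hydrogen in place of chloro on an aromatic carbon. Going by the values given here, this is the same kind of change as the one from compound 2 to compound 1, not the same: there the hydrogen enters ortho to a nitro group and meta to a large group, here it enters ortho to a large group and meta to a chloro group.

The measured step of this kind stayed within the scatter, so a small step is expected from compound 3 to compound 4 as well; the expectation is uncertain because compound 3 gives only the limit < 22.4 10^-6 cm/s, so the starting point is not known. The step is expected to be an at least 1.3-fold higher number from compound 3 to compound 4 (0.12 log units; that floor lies within the scatter). Compound 4 is expected to give about 30 10^-6 cm/s in this assay, estimated between 10 10^-6 cm/s and 90 10^-6 cm/s, with a fair chance that only a limit is reported again.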

Compound 4, apparent permeability: 297 10^-6 cm/s
Beside the measured number, compound 4's estimate is 9.9-fold (1.00 log units) below it; measured number outside the range, above it.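

In this assay, hydrogen in place of chloro on an aromatic carbon gives an at least 13-fold higher number from compound 3 to compound 4 (1.12 log units; beyond the scatter). This replacement does not carry from one core to another as a step of fixed size: the same change on two cores in this assay, a 1.9-fold higher number (0.27 log units; within the scatter) from compound 2 to compound 1 and an at least 13-fold higher number (1.12 log units; beyond the scatter) from compound 3 to compound 4, at least 7.0-fold (0.85 log units) apart, beyond the scatter of two such steps

Compound 3 stands at a limit of the assay and not at a number, so its step gives only a floor and the full gap between the two steps stays unknown: the limit of < 22.4 10^-6 cm/s in this assay, at which 1 of the 4 values shown sits.

The pair shows that this replacement can be small on one core and large on another, but two instances do not show which feature of the cores sets the difference, and they give no rule for a further core.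

Chloro in place of nitro on an aromatic carbon gives a 2.3-fold higher number from compound 1 to compound 4 (0.37 log units; beyond the scatter), which rests on one pair alone, so it remains open whether that step would hold on another core. Also open, as far as these compounds go, is how an amine, a carboxylic acid or a methoxy group on the same aromatic carbon would read in this assay, and how large the step from chloro to hydrogen would be on cores carrying those groups.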